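Adding an Amine Chain to Compound 1

The source may report more compounds than this note shows. Statements on the series, on what has been measured and on what is new or still open speak of the compounds shown alone.

Compound 1 (`Cn1c(N)c(-c2nc3ccccc3[nH]2)c2nc(C#N)c(C#N)nc21`) offers only a limit as a starting point. In a functional assay on HL60/MX2 cells (Homo sapiens) for antiproliferative activity, read by MTT assay, with a stated time of 48 h (a higher number here means a weaker inhibitor, a lower number a stronger inhibitor), compound 1 gives > 50000 nM, which is a limit of the assay and not a number. Compound 2 (`N#Cc1nc2c(-c3nc4ccccc4[nH]3)c(N)n(CCO)c2nc1C#N`) gives > 50000 nM, again a limit. Two of the three results thus sit at the limit of > 50000 nM in this assay, at which 2 of the 3 values shown sit, and the change between those compounds is a step that the two limits leave unreadable from compound 1 to compound 2. For the measured compounds named here, compound 3 (`N#Cc1nc2c(-c3nc4ccccc4[nH]3)c(N)n(CCCN3CCCCC3)c2nc1C#N`) is the only one with a real number, at 1010 nM.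

Compound 4 (`CCN(CC)CCCCn1c(-c2c(N)n(C)c3nc(C#N)c(C#N)nc23)nc2ccccc21`) differs from compound 1 by 4-(diethylamino)butyl in place of hydrogen on an aromatic nitrogen. The nearest precedents are the steps to compound 3, namely an at least 49-fold lower number from compound 1 to compound 3 (1.69 log units; beyond the scatter) and an at least 49-fold lower number from compound 2 to compound 3 (1.69 log units; beyond the scatter). Both introduce a piperidin-1-yl group, but on a saturated chain carbon rather than on the aromatic nitrogen of the five-membered ring, so they guide this change only loosely. Compound 2 shows that not every added chain gives a readable value in this assay. A large move towards a lower number is nevertheless expected, on the strength of an at least 49-fold lower number from compound 1 to compound 3 (1.69 log units; beyond the scatter). The expected step is an at least 20-fold lower number from compound 1 to compound 4 (1.30 log units; beyond the scatter). For compound 4 the estimated value is 2500 nM, with an expected range of 500 nM to 15000 nM.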

Compound 4, half-maximal inhibitory concentration: 3920 nM
The estimate for compound 4 lay 1.6-fold (0.20 log units) below the measured number; the range from low to high includes it.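

In this assay, 4-(diethylamino)butyl on the aromatic nitrogen of the five-membered ring gives an at least 12-fold lower number from compound 1 to compound 4 (1.10 log units; beyond the scatter). For the compounds shown here, this nitrogen still bears its hydrogen in compound 2 and compound 3, so the result shows for the first time that a change at this position, with an amine chain, also gives a readable number. A readable value therefore no longer rests on compound 3 and its chain alone, although the true size of the step stays unknown because compound 1 rests at a limit of the assay: the limit of > 50000 nM in this assay, at which 2 of the 4 values shown sit.

Compound 3 and compound 4 differ in more than one place, so the compounds shown do not separate the effect of the position from that of the chain or its amine. As far as these compounds go, it remains open whether a plain butyl chain without an amine, a 2-hydroxyethyl chain, or a shorter chain ending in piperidin-1-yl on this same aromatic nitrogen would also give a readable number in this assay.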